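Swapping the end group on a shared chain

The compounds below may be only part of what the source reports. "The series", "measured", "known", "first", "only" and "open" are said of these compounds alone.

- compound 1 `COc1ccccc1N1C(=O)CSC1c1cccc(C(=O)NCCCCc2ccc(Cl)cc2)c1` gives 78.6 nM
- compound 2 `COc1ccccc1N1C(=O)CSC1c1cccc(C(=O)NCCCCc2cccs2)c1` gives 46 nM

These values come from a functional assay on HOS-TE85 cells (Homo sapiens) for inhibition, read by CCK-8 assay, with a stated time of 72 h (a higher number here means a weaker inhibitor, a lower number a stronger inhibitor), and lie within the usual scatter of each other, so compound 2 stands level with compound 1 on the data so far. Compound 3 `COc1ccccc1N1C(=O)CSC1c1cccc(C(=O)NCCCCN2C(=O)C=CC2=O)c1` keeps the shared core and changes only the end group of the chain: a group of 7 heavy atoms (4 carbon, 1 nitrogen, 2 oxygen; one five-membered non-aromatic ring with 1 hetero atom) in place of a group of 5 heavy atoms (4 carbon, 1 sulfur; one five-membered aromatic ring with 1 hetero atom), on a saturated chain carbon, four bonds along the chain from an amide-type nitrogen. Among the compounds with values here, one measured step bears on this, a swap of end groups at the same place: a 1.7-fold lower number from compound 1 to compound 2 (0.23 log units; within the scatter). That single step is thin evidence, and the entering ring, unlike the two groups before it, is non-aromatic, so the range stays wide. No step beyond the scatter is therefore expected in this assay, in either direction. For compound 3 the estimated value is 60 nM, with an expected range from 15 nM to 250 nM. This estimate means an expected 1.3-fold higher number from compound 2 to compound 3 (0.12 log units; within the scatter).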

Compound 3, half-maximal inhibitory concentration: > 1000 nM
Compound 3 ended at the assay's limit (the forecaster's own chance of this, stated with the estimate: 3%); at least 16-fold (1.22 log units) between middle value and limit.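

In this assay compound 3 gives > 1000 nM, which is a limit of the assay and not a number. Placing the five-membered non-aromatic ring at the end of the chain gives an at least 21-fold higher number from compound 2 to compound 3 (1.33 log units; beyond the scatter), and the same ring gives an at least 12-fold higher number from compound 1 to compound 3 (1.10 log units; beyond the scatter). The step between the two aromatic end groups stayed within the scatter, so only now does this position prove sensitive to the choice of end group, though the full size of the loss cannot be read from a limit: the limit of > 1000 nM in this assay, at which 1 of the 3 values shown sits.

The compounds shown do not tell whether the loss goes with leaving an aromatic ring behind or with something particular to this ring. A saturated ring such as pyrrolidin-1-yl, or an open amine at the same chain end, would help separate these two readings.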